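The compounds below may be only part of what the source reports. "The series", "measured", "known", "first", "only" and "open" are said of these compounds alone.

Compound 1: `O=C(Nc1cccc(-n2cc(-c3ccncc3)c(-c3ccc(Cl)c(O)c3)n2)c1)Nc1cccc(C(F)(F)F)c1` — > 32500 nM
Compound 2: `COc1cc(-c2nn(-c3cccc(NC(=O)Nc4ccc(Cl)c(Cl)c4)c3)cc2-c2ccncc2)ccc1Cl` — > 50000 nM

Both values in a functional assay on NCI-H322M cells (Homo sapiens) for inhibition, read by sulforhodamine B assay, with a stated time of 48 h (a lower number here means that less compound is tolerated, a higher number that more compound is tolerated), are limits, not numbers. Compound 1 gives > 32500 nM, which is a limit (the limit of > 32500 nM in this assay, at which 1 of the 2 values shown sits). Compound 2 gives > 50000 nM, likewise a limit (the limit of > 50000 nM in this assay, at which 1 of the 2 values shown sits), so compound 2 stands only at a limit with no number behind it. Compound 3 `O=C(Nc1cccc(-n2cc(-c3ccncc3)c(-c3ccc(Cl)c(O)c3)n2)c1)Nc1ccc(Cl)c(Cl)c1` differs from compound 2 by hydrogen in place of methyl on an oxygen on an aromatic ring. Among the compounds with values here, no measured pair exists to size this step. Compound 1 already carries the hydroxy group and sits at a limit (the limit of > 32500 nM in this assay, at which 1 of the 2 values shown sits), so no shift beyond the scatter is expected. The expected step is a number no higher from compound 2 to compound 3 (the limit leaves the size open). Compound 3 is estimated at 50000 nM, between 20000 nM and 100000 nM, most likely reported again only as a limit.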

Compound 3, concentration lethal to 50% of the cells: > 32500 nM
Compound 3 was reported as a limit; the forecaster's own chance of this, stated with the estimate: 75%; the middle value does not contradict the limit.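

Compound 1, compound 2 and compound 3 all stand at limits, so the changes linking compound 3 to compound 2 and to compound 1 cannot be read as steps. From the compounds shown here alone, whether either change affects the lethal concentration stays open.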